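A Shorter Chain in Place of a Ring

The source may report more compounds than this note shows. Statements on the series, on what has been measured and on what is new or still open speak of the compounds shown alone.

Three compounds share a core in which a cyclic urea sits on one aromatic ring, joined through a sulfonamide to a second aromatic ring that carries the variable group. In a functional assay on M21 cells (Homo sapiens) for antiproliferative activity, read by sulforhodamine B assay, with a stated time of 48 h (on this read-out lower numbers stand for stronger inhibition and higher numbers for weaker inhibition), compound 2 `O=C1NCCN1c1ccc(S(=O)(=O)Nc2ccc3[nH]ccc3c2)cc1` gives 87 nM, and compound 3 `COc1ccc(NS(=O)(=O)c2ccc(N3CCNC3=O)cc2)cc1OC` gives 340 nM. Compound 1 `O=C1NCCN1c1ccc(S(=O)(=O)Nc2ccc(C3CCCCC3)cc2)cc1` carries a cyclohexyl group and reaches only the limit of the measurement, > 1000 nM, so its true value is not known. Among the three values shown, compound 1 alone sits at the limit of > 1000 nM in this assay, at which 1 of the 3 values shown sits.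

Compound 4 `CCCCc1ccc(NS(=O)(=O)c2ccc(N3CCNC3=O)cc2)cc1` differs from compound 1 in one place: butyl in place of cyclohexyl on an aromatic carbon. Both the group that leaves and the group that enters are built of carbon only, and the change is a modest one in shape rather than in kind. Going by the values given here, no measured pair in this set shows what such a change does in this assay, so the expectation rests on compound 1 alone, whose limit gives only a floor.

Compound 4 is therefore expected to remain weak, with a step that the limit leaves unreadable from compound 1 to compound 4 that is expected to stay within the usual scatter. Compound 4 is estimated at 1500 nM, expected to fall between 400 nM and 6000 nM, and the measurement may well again return only a limit rather than a number.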

Compound 4, half-maximal inhibitory concentration: 450 nM
Compound 4: middle estimate off by 3.3-fold (0.52 log units), on the high side; the measured number falls inside the stated range.
By their numbers in this assay, from the lowest: compound 2; then compounds 3 and 4 (each within the scatter of the next). At a limit, above all of these: compound 1.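

Going by these compounds alone, this pair is the first in the set that differ in one place, and it shows that the group on this aromatic carbon, para to a large group, matters for activity. In this assay, butyl in place of cyclohexyl gives an at least 2.2-fold lower number from compound 1 to compound 4 (0.34 log units; beyond the scatter), so a change from a carbon ring to an open carbon chain is enough to move the number beyond the usual scatter, even though neither group has any hydrogen-bond donors or acceptors. The full size of this step cannot be read, because compound 1 stands only at a limit of the assay: the limit of > 1000 nM in this assay, at which 1 of the 4 values shown sits.

The pair cannot separate the loss of the ring from the shortening of the carbon count, since both change together in compound 4. From the compounds shown here alone, whether a longer chain such as hexyl, which would remove the ring without shortening the carbon count, or an amine in the same place would lower the number further remains open.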